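This account rests on a few compounds, and the source may have more. Where it says the series, first, only, none or still open, it means among the compounds named here.

Measured compounds:
Compound 1 `CCC(C(=O)N1CCN(c2cccc(Cl)c2)CC1)N1C(=O)CCC1=O` gave 0%
Compound 2 `CC(C(=O)N1CCN(c2ccccc2C(F)(F)F)CC1)N1C(=O)CCC1=O` gave 25%

Both compounds were tested in a functional assay on the whole organism (strain Swiss) with Mus musculus as the target, in the maximal electroshock model, with a stated time of 1 h, at a dose of 100 mg/kg by the intraperitoneal route; on this read-out higher numbers stand for a stronger effect at the one dose given and lower numbers for a weaker effect. Compound 1 stands at the bottom of the two numbers: it showed 0%, while compound 2 showed 25%, a gap that lies beyond the usual scatter of this kind of test. Nothing more can be read from this pair, since the two compounds differ in more than one place.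

Compound 3 `CCC(C(=O)N1CCN(c2ccccc2F)CC1)N1C(=O)CCC1=O` has not yet been measured. It differs from compound 1 in a single place: 2-fluorophenyl in place of 3-chlorophenyl on an amine nitrogen in a ring. No change of exactly this kind has been measured here, so the expectation rests only on the two values at hand. A small rise from compound 1 is expected, with compound 3 estimated at 15% in this assay, within 0% to 40%. The step of a number 15 percentage points higher from compound 1 to compound 3 (beyond the scatter) is expected to be small, barely beyond the scatter if at all.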

Compound 3, a percentage reported as activity, at one dose (the size of the read-out at that dose, not a potency): 0%
Compound 3: middle estimate off by 15 percentage points, on the high side, within the range that was stated.
By their numbers in this assay, from the lowest: compounds 1 and 3 (each within the scatter of the next); then compound 2.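

In this assay, placing 2-fluorophenyl where compound 1 has 3-chlorophenyl, on the amine nitrogen in the ring, gives no change at the digits printed from compound 1 to compound 3 (within the scatter) for this first comparison that differs in one place only. With the rest of the molecule held the same, this exchange of one halogen-bearing phenyl group for another therefore does not separate the two compounds at the one dose given. Nothing available here accounts for this result.

The compounds shown leave open whether a different group on the phenyl ring at this place, such as a nitrile or a methoxy group, would give a read-out that differs from that of compound 1. They also leave open how a longer chain on the shared core would alter the read-out with either of these two phenyl groups in place.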